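Cyano for trifluoromethyl on the aryl ring of compound 3

The source may report more compounds than this note shows. Statements on the series, on what has been measured and on what is new or still open speak of the compounds shown alone.

Three amides sharing one core have been measured in a functional assay on the whole organism (integument) for inhibition, with Chilo suppressalis as the target, read by scintillation counting, with a stated time of 72 h, in the presence of a further agent that is not named here; on this read-out higher numbers stand for weaker inhibition and lower numbers for stronger inhibition. Compound 1 `COc1cccc(OC)c1C(=O)Nc1nnc(-c2ccc(C)cc2)s1` gives 85.1 nM, compound 2 `COc1cccc(OC)c1C(=O)Nc1nnc(-c2ccc(C(C)(C)C)cc2)s1` gives 525 nM, and compound 3 `COc1cccc(OC)c1C(=O)Nc1nnc(-c2ccc(C(F)(F)F)cc2)s1` gives 56.2 nM. Compound 3 has the lowest number of the three; its nearest neighbour is compound 1, with a 1.5-fold lower number from compound 1 to compound 3 (0.18 log units; within the scatter), and its furthest is compound 2, with a 9.3-fold lower number from compound 2 to compound 3 (0.97 log units; beyond the scatter). The step of a 6.2-fold higher number from compound 1 to compound 2 (0.79 log units; beyond the scatter) completes the picture.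

Compound 4 `COc1cccc(OC)c1C(=O)Nc1nnc(-c2ccc(C#N)cc2)s1` differs from compound 3 in one place: cyano in place of trifluoromethyl on an aromatic carbon. Among the compounds with values here, no measured step involves a cyano group, so only the two steps ending at trifluoromethyl bear on it indirectly, and they show that the exchange of one group for another on this aromatic carbon has moved the number by at most the size seen between compound 2 and compound 3. For compound 4 the change is therefore expected to stay within the scatter, so a 1.2-fold higher number from compound 3 to compound 4 (0.10 log units; within the scatter) is estimated. Compound 4 is expected to give 70 nM, between 25 nM and 200 nM.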

Compound 4, half-maximal inhibitory concentration: 200 nM
Compound 4: the middle estimate sits 2.9-fold (0.46 log units) below what was measured, and the stated range covers the measured number.
By their numbers in this assay, from the lowest: compounds 3 and 1 (each within the scatter of the next); then compound 4; then compound 2.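

In this assay, within the data shown here, the earlier compounds set only tert-butyl apart at this aromatic carbon, while methyl and trifluoromethyl stayed within the scatter of each other; cyano now stands apart from both, with a 3.6-fold higher number from compound 3 to compound 4 (0.55 log units; beyond the scatter) and a 2.4-fold higher number from compound 1 to compound 4 (0.37 log units; beyond the scatter). Cyano does not match tert-butyl either, with a 2.6-fold lower number from compound 2 to compound 4 (0.42 log units; beyond the scatter), so the four groups at this position now fall on three separate levels rather than two. Nothing available accounts for this order.

The compounds shown leave open where other groups on this aromatic carbon, such as an amine, a carboxylic acid or a methoxy group, would fall on these levels. They also leave open whether the same order would hold with a different amide part on the shared core.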